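The source may report more compounds than this note shows. Statements on the series, on what has been measured and on what is new or still open speak of the compounds shown alone.

Values measured in a functional assay on DU-145 cells (Homo sapiens) for antiproliferative activity, read by MTT assay, with a stated time of 72 h (on this read-out lower numbers stand for stronger inhibition and higher numbers for weaker inhibition), are these.

Compound 1 `COc1cc2c(Nc3ccc(C#N)cc3)ncnc2cc1OCCCN(C)C` gives 35300 nM
Compound 2 `COc1cc2c(Nc3ccc(C#N)cc3)ncnc2cc1OCCCN1CCCC1` gives 14400 nM
Compound 3 `COc1cc2c(Nc3ccc(C#N)cc3)ncnc2cc1OCCCN1CCC(C)CC1` gives 16600 nM

Compound 3 shares the lower part of this small range with one neighbour, the closest gap being a 1.2-fold higher number from compound 2 to compound 3 (0.06 log units; within the scatter) and the widest being a 2.1-fold lower number from compound 1 to compound 3 (0.33 log units; beyond the scatter) on these numbers.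

Compound 4 `COc1cc2c(Nc3ccc(C#N)cc3)ncnc2cc1OCCCN1CCC(CO)CC1` differs from compound 3 at one place. The change is hydroxy in place of hydrogen on a saturated chain carbon bound to a saturated ring carbon and reads as hydroxy in place of hydrogen on a saturated chain carbon bound to a saturated ring carbon, so that 4-methylpiperidin-1-yl becomes 4-(hydroxymethyl)piperidin-1-yl.

Within the data shown here, no measured step adds a hydroxy, so the data hold no direct precedent. The nearest guides are the swaps among dimethylamino, pyrrolidin-1-yl and 4-methylpiperidin-1-yl. These gave a 2.5-fold lower number from compound 1 to compound 2 (0.39 log units; beyond the scatter) and a 2.1-fold lower number from compound 1 to compound 3 (0.33 log units; beyond the scatter) as modest moves, and a 1.2-fold higher number from compound 2 to compound 3 (0.06 log units; within the scatter) as no real move. Even whole-group swaps moved the number little, so a smaller edit is expected to leave this assay without a clear shift in either direction. The estimated step is a 1.1-fold higher number from compound 3 to compound 4 (0.04 log units; within the scatter) and would stay inside the usual scatter. Compound 4 is expected at 18000 nM as an estimate, with an estimated range of 7000 nM to 45000 nM.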

Compound 4, half-maximal inhibitory concentration: 53200 nM
Compound 4: the middle estimate sits 3.0-fold (0.47 log units) below what was measured, and the stated range ends below it.
By their numbers in this assay, from the lowest: compounds 2 and 3 (each within the scatter of the next); then compounds 1 and 4 (each within the scatter of the next).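

In this assay, adding one oxygen to the far end of the amine group gives a 3.2-fold higher number from compound 3 to compound 4 (0.51 log units; beyond the scatter) and so moves the number beyond the scatter towards weaker inhibition. The earlier swaps at this end of the chain either lowered the number or stayed within the scatter, so this is the first change here shown to weaken the read-out, and the comparison with the pyrrolidine compound, a 3.7-fold higher number from compound 2 to compound 4 (0.57 log units; beyond the scatter), points the same way. Against the open-chain dimethylamino group, the result is a 1.5-fold higher number from compound 1 to compound 4 (0.18 log units; within the scatter), so compound 4 does not keep the advantage that compound 2 and compound 3 show over compound 1, which means a saturated ring on the chain does not by itself bring a lower number. Nothing measured here gives a reason for this shift. The compounds shown leave open whether the free hydroxy itself matters or simply the extra atom at that spot, which a methoxymethyl group on the same ring could help separate. They also leave open how a hydroxy set directly on the ring, as in 4-hydroxypiperidin-1-yl, or a longer 2-hydroxyethyl chain would read in this assay on this core.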